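The source may hold more compounds than are shown below. What is called first, only, known or untested is meant among the compounds shown, and "the series" means these compounds.

Notes on the series. Compound 1 `CCCN(CCC(F)(F)F)Cc1c(C(F)(F)F)nc2n(-c3c(C)cc(C)cc3C)c(Cl)cn12` gives 12 nM in an assay on cells for displacement of a labelled ligand from corticotropin-releasing factor receptor 1 (Homo sapiens), with a stated time of 100 min; on this read-out higher numbers stand for weaker inhibition and lower numbers for stronger inhibition. Compound 2 `Cc1cc(C)c(-n2c(Cl)cn3c(CN(C)Cc4ccccc4)c(C(F)(F)F)nc23)c(C)c1` gives 160 nM, and compound 3 `CCCN(Cc1ccccc1)Cc1c(C(F)(F)F)nc2n(-c3c(C)cc(C)cc3C)c(Cl)cn12` gives 170 nM. The steps of a 13-fold higher number from compound 1 to compound 2 (1.12 log units; beyond the scatter) and a 14-fold higher number from compound 1 to compound 3 (1.15 log units; beyond the scatter) are large, whereas a 1.1-fold higher number from compound 2 to compound 3 (0.03 log units; within the scatter) stays within the scatter. Compound 3 therefore carries the highest number of the three, with compound 2 within the scatter of it and compound 1 far lower.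

Compound 4 `CCN(Cc1ccccc1)Cc1c(C(F)(F)F)nc2n(-c3c(C)cc(C)cc3C)c(Cl)cn12` differs from compound 3 by hydrogen in place of methyl on a saturated chain carbon, two bonds along the chain from an amine nitrogen. Going by the values given here, the only measured step on that chain, a 1.1-fold higher number from compound 2 to compound 3 (0.03 log units; within the scatter), changed nothing beyond the scatter, so no step beyond the scatter is expected in this assay here either. For compound 4 the expected step is no change at the digits printed from compound 3 to compound 4 (within the scatter). Compound 4 is estimated at 170 nM, with a range from 80 nM to 360 nM.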

Compound 4, inhibition constant: 350 nM
Compound 4: middle estimate off by 2.1-fold (0.31 log units), on the low side; the range from low to high includes it.
By their numbers in this assay, from the lowest: compound 1; then compounds 2 and 3 (each within the scatter of the next); then compound 4.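

Trimming propyl to ethyl on benzyl(propyl)amino gives a 2.1-fold higher number from compound 3 to compound 4 (0.31 log units; beyond the scatter) in this assay, so this position does respond to a single methyl, though modestly. With a 2.2-fold higher number from compound 2 to compound 4 (0.34 log units; beyond the scatter) as well, the ethyl compound stands apart from both its neighbours, while compound 2 and compound 3 lie within the scatter of each other, so the number does not follow chain length steadily. The trifluoropropyl-bearing amine remains far ahead, with a 29-fold higher number from compound 1 to compound 4 (1.46 log units; beyond the scatter).

Nothing available explains the upturn at ethyl. As far as these compounds go, whether a butyl chain on this nitrogen would keep the number near that of compound 3 remains open.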